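Two Small Changes on One Core in a Cell Assay

This account rests on a few compounds, and the source may have more. Where it says the series, first, only, none or still open, it means among the compounds named here.

Compound 1 `COc1ccc2[nH]c(-c3ccccc3)c(C(c3c(-c4ccccc4)[nH]c4ccc(C)cc34)C3C(=O)NN=C3C)c2c1` carries a methoxy group and a methyl group on two of its aromatic carbons. In a functional assay on HeLa cells (Homo sapiens) for cytotoxicity, read by MTT assay (a higher number here means a weaker inhibitor, a lower number a stronger inhibitor), compound 1 gives > 100000 nM, which is a limit of the measurement rather than a number. Compound 2 `CC1=NNC(=O)C1C(c1c(-c2ccccc2)[nH]c2ccccc12)c1c(-c2ccccc2)[nH]c2ccc(C)cc12` differs from compound 1 by hydrogen in place of methoxy on an aromatic carbon. In this assay compound 2 gives > 100000 nM, again only a limit. The step that the two limits leave unreadable from compound 1 to compound 2 therefore cannot be read, because both values sit at the limit of > 100000 nM in this assay, at which 2 of the 3 values shown sit. Compound 3 `COc1ccc2[nH]c(-c3ccccc3)c(C(c3c(-c4ccccc4)[nH]c4ccc(Cl)cc34)C3C(=O)NN=C3C)c2c1` differs from compound 1 by chloro in place of methyl on an aromatic carbon. In this assay, for the measured compounds named here, compound 3 gives 1200 nM, the only true number among the three. The step of an at least 83-fold lower number from compound 1 to compound 3 (1.92 log units; beyond the scatter) is the one clear finding so far. Compound 4 `CC1=NNC(=O)C1C(c1c(-c2ccccc2)[nH]c2ccccc12)c1c(-c2ccccc2)[nH]c2ccc(Cl)cc12` is not yet measured; it differs from compound 3 by hydrogen in place of methoxy on an aromatic carbon, the same change as from compound 1 to compound 2, where its size stayed hidden behind the limit. That earlier step gave no usable reading. With nothing pointing either way, the step from compound 3 to compound 4 is expected to be small, a 1.3-fold higher number from compound 3 to compound 4 (0.10 log units; within the scatter). Compound 4 is thus estimated at 1500 nM in this assay, with a likely range from 400 nM to 6000 nM.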

Compound 4, half-maximal inhibitory concentration: 29800 nM
Compound 4: the middle estimate sits 20-fold (1.30 log units) below what was measured; measured number above the stated range.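

Chloro in place of methyl gives an at least 3.3-fold lower number from compound 2 to compound 4 (0.52 log units; beyond the scatter) in this assay, so this change lowers the number on both the core with the methoxy group and the core without it. This shows the same direction on two cores, but not that the size carries over, since only a lower bound can be given for each step: the same change on two cores in this assay, an at least 83-fold lower number (1.92 log units; beyond the scatter) from compound 1 to compound 3 and an at least 3.3-fold lower number (0.52 log units; beyond the scatter) from compound 2 to compound 4; the limit leaves it open whether they differ

Hydrogen in place of methoxy gives a 25-fold higher number from compound 3 to compound 4 (1.40 log units; beyond the scatter), a clear loss on the chloro core, while the same change from compound 1 to compound 2 cannot be read, so there is no second reading to show whether that loss carries to the methyl core: the limit of > 100000 nM in this assay, at which 2 of the 4 values shown sit.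

The compounds shown cover only methoxy or hydrogen at one place and chloro or methyl at the other. Going by these compounds, it remains open whether a bromo group in place of chloro, or a hydroxyl group or an amine in place of methoxy, would give a lower or a higher number.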